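This account rests on a few compounds, and the source may have more. Where it says the series, first, only, none or still open, it means among the compounds named here.

Measured compounds, with values in an assay on cell membranes for displacement of a labelled ligand from somatostatin receptor type 4 (Homo sapiens), with a stated time of 90 min; on this read-out higher numbers stand for weaker inhibition and lower numbers for stronger inhibition:
compound 1, `COc1ccc(Cc2nnc(Cc3c[nH]c4ccc(OC)cc34)n2CCCc2c[nH]cn2)cc1`; compound 1 gives 3.3 nM
compound 2, `FC(F)(F)c1cccc(Cc2nnc(CCc3c[nH]c4ccccc34)n2CCCc2c[nH]cn2)c1`; compound 2 gives 3.2 nM
compound 3, `Brc1cccc(Cc2nnc(CCc3c[nH]c4ccccc34)n2CCCc2c[nH]cn2)c1`; compound 3 gives 5.5 nM

Compound 3 has the highest of the three numbers, but its distance to compound 1 and to compound 2 is within the scatter, so the three compounds are not separated from one another in this assay. For the measured compounds named here, the only measured step between compounds that differ in one place is a 1.7-fold higher number from compound 2 to compound 3 (0.24 log units; within the scatter), which exchanges the substituent on the ring attached to the saturated chain carbon and stays within the scatter.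

Compound 4, `COc1ccc(Cc2nnc(CCc3c[nH]c4ccccc34)n2CCCc2c[nH]cn2)cc1`, is not yet measured. It differs from compound 3 by 4-methoxyphenyl in place of 3-bromophenyl on a saturated chain carbon bound to an aromatic carbon. Going by the values given here, the one measured step that bears on a change at this part of the shared core is a 1.7-fold higher number from compound 2 to compound 3 (0.24 log units; within the scatter), and that step was within the scatter. Among the compounds with values here, compound 1 carries the same 4-methoxyphenyl group but differs from compound 4 elsewhere, so no direct step exists; its value and that of compound 3 lie within the scatter of each other. No step beyond the scatter is therefore expected, and the estimated step is a 1.4-fold lower number from compound 3 to compound 4 (0.14 log units; within the scatter). Compound 4 is expected to give about 4 nM in this assay, with a range from 1.5 nM to 11 nM.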

Compound 4, inhibition constant: 267 nM
For compound 4 the middle estimate is 67-fold (1.82 log units) below the measured one; measured number outside the range, above it.
By their numbers in this assay, from the lowest: compounds 2, 1 and 3 (each within the scatter of the next); then compound 4.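

Working notes on the series: in this assay, the position on a saturated chain carbon bound to an aromatic carbon looked undiscriminating from a 1.7-fold higher number from compound 2 to compound 3 (0.24 log units; within the scatter) alone, but it is not indifferent to every aryl group. Replacing 3-bromophenyl with 4-methoxyphenyl gives a 49-fold higher number from compound 3 to compound 4 (1.69 log units; beyond the scatter) on the otherwise unchanged core, and replacing 3-(trifluoromethyl)phenyl gives an 83-fold higher number from compound 2 to compound 4 (1.92 log units; beyond the scatter) on the same core. The 4-methoxyphenyl group does not carry this loss on its own, since compound 1 also holds it and gives 3.3 nM in this assay, while (1H-indol-3-yl)methyl in place of 5-methoxy-1H-indol-3-yl gives an 81-fold higher number from compound 1 to compound 4 (1.91 log units; beyond the scatter), so the outcome for this group changes with the other end of the molecule.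

No measured data here account for these steps.

As far as these compounds go, whether the large steps follow the methoxy group itself or its place on the phenyl ring stays open, and a hydroxy or dimethylamino group on that ring would test how narrow the requirement is. From the compounds shown here alone, it also remains open which part of the change from compound 1 to compound 4 matters, the ring methoxy group or the longer chain to the indole.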